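Swapping a saturated ring for an aromatic one on sulfur

The compounds below may be only part of what the source reports. "The series", "measured", "known", "first", "only" and "open" are said of these compounds alone.

Compound 3 `Cn1c(-c2ccc(NC(=O)CSC3=NCCS3)cc2)nc(-c2ccccc2)c1-c1ccccc1` stands lowest of the three measured compounds in a functional assay on MCF7 cells (Homo sapiens) for cytotoxicity, read by MTT assay, with a stated time of 24 h, tested at 6.4 ug/mL (on this read-out higher numbers stand for a stronger effect at the one concentration tested and lower numbers for a weaker effect), where compound 3 gives 18.6%. Compound 1 `Cc1ccc2oc(SCC(=O)Nc3ccc(-c4nc(-c5ccccc5)c(-c5ccccc5)n4C)cc3)nc2c1` gives 24.6%, and compound 2 `Cn1nnnc1SCC(=O)Nc1ccc(-c2nc(-c3ccccc3)c(-c3ccccc3)n2C)cc1` gives 55.9%; the step of a number 6 percentage points lower from compound 1 to compound 3 (within the scatter) is small, while a number 37.3 percentage points lower from compound 2 to compound 3 (beyond the scatter) is large. Compound 4 `Cn1ccnc1SCC(=O)Nc1ccc(-c2nc(-c3ccccc3)c(-c3ccccc3)n2C)cc1` differs from compound 3 by a group of 6 heavy atoms (4 carbon, 2 nitrogen; one five-membered aromatic ring with 2 hetero atoms) in place of a group of 5 heavy atoms (3 carbon, 1 nitrogen, 1 sulfur; one five-membered non-aromatic ring with 2 hetero atoms), on a sulfur. Both measured steps bear on this move: a number 37.3 percentage points lower from compound 2 to compound 3 (beyond the scatter) shows a large loss when the aromatic ring with four hetero atoms was replaced by the non-aromatic ring, whereas a number 6 percentage points lower from compound 1 to compound 3 (within the scatter) shows little change from the fused aromatic ring. An aromatic ring with two hetero atoms sits between these cases, so a moderate rise in this assay is expected. Compound 4 is therefore estimated at 35%, with a range from 15% to 58%. The expected step is a number 16.4 percentage points higher from compound 3 to compound 4 (beyond the scatter).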

Compound 4, a percentage reported as activity, at one concentration (the size of the read-out at that concentration, not a potency): 27.2%
Compound 4: middle estimate off by 7.8 percentage points, on the high side; the range from low to high includes it.
By their numbers in this assay, from the lowest: compounds 3, 1 and 4 (each within the scatter of the next); then compound 2.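

In this assay, the 1-methyl-1H-imidazol-2-yl ring on the sulfur cannot be told apart from the non-aromatic ring (a number 8.6 percentage points higher from compound 3 to compound 4 (within the scatter)) or from the fused 5-methyl-1,3-benzoxazol-2-yl ring (a number 2.6 percentage points higher from compound 1 to compound 4 (within the scatter)). A five-membered aromatic ring alone therefore does not reach the level of the 1-methyl-1H-tetrazol-5-yl ring (a number 28.7 percentage points lower from compound 2 to compound 4 (beyond the scatter)). No measurement here accounts for that gap. As far as these compounds go, whether a triazole ring or an open-chain amine on the sulfur would match the tetrazole stays open.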